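Methyl on the pyrazole nitrogen chain: compound 4 expected

The source may hold more compounds than are shown below. What is called first, only, known or untested is meant among the compounds shown, and "the series" means these compounds.

Measured so far in a functional assay on HCT-116 cells (Homo sapiens) for inhibition; a higher number here means a weaker inhibitor, a lower number a stronger inhibitor:
compound 1 `CCNC(=O)c1noc(-c2cc(C(C)C)c(O)cc2O)c1-c1cc(C(=O)NC)no1` gives 124 nM;
compound 2 `CCNC(=O)c1cc(-c2c(C(=O)NCC)noc2-c2cc(C(C)C)c(O)cc2O)on1` gives 14 nM;
compound 3 `CCNC(=O)c1noc(-c2cc(C(C)C)c(O)cc2O)c1-c1cnn(C)c1` gives 41 nM.

Compound 4 `CCNC(=O)c1noc(-c2cc(C(C)C)c(O)cc2O)c1-c1cnn(CC)c1` is not yet measured. It differs from compound 3 by methyl in place of hydrogen on a saturated chain carbon bound to an aromatic nitrogen. The same kind of change has been measured once: compound 2 differs from compound 1 by methyl in place of hydrogen on a saturated chain carbon bound to an amide-type nitrogen, and that step was an 8.9-fold lower number from compound 1 to compound 2 (0.95 log units; beyond the scatter). The cores of compound 1 and compound 3 differ by 1-methyl-1H-pyrazol-4-yl in place of 3-(methylcarbamoyl)-1,2-oxazol-5-yl on an aromatic carbon, so the change is now made in a different setting: a chain carbon bound to an aromatic nitrogen rather than to an amide-type nitrogen. Because the earlier step of an 8.9-fold lower number from compound 1 to compound 2 (0.95 log units; beyond the scatter) sat at a different place, only a smaller improvement is expected here, estimated as a 2.1-fold lower number from compound 3 to compound 4 (0.31 log units; beyond the scatter). Compound 4 is therefore expected to give about 20 nM, likely between 8 nM and 50 nM.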

Compound 4, half-maximal inhibitory concentration: 26 nM
The estimate for compound 4 lay 1.3-fold (0.11 log units) below the measured number; low and high end bracket the measured number.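

Carrying this methyl to another core did not carry the size of its effect: in this assay, going from 1-methyl-1H-pyrazol-4-yl to 1-ethyl-1H-pyrazol-4-yl gives a 1.6-fold lower number from compound 3 to compound 4 (0.20 log units; within the scatter) and the two steps differ: the same change on two cores in this assay, an 8.9-fold lower number (0.95 log units; beyond the scatter) from compound 1 to compound 2 and a 1.6-fold lower number (0.20 log units; within the scatter) from compound 3 to compound 4, 5.6-fold (0.75 log units) apart, beyond the scatter of two such steps

Compound 4 reads a 1.9-fold higher number from compound 2 to compound 4 (0.27 log units; within the scatter) and a 4.8-fold lower number from compound 1 to compound 4 (0.68 log units; beyond the scatter) so it cannot be told apart from compound 2 but clearly improves on compound 1. Still, this is one pair on each core, and the methyl sits on a different kind of chain, so these data cannot separate the effect of the core from the effect of the place.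

As far as these compounds go, it remains open whether a longer chain, such as propyl, or a chain ending in an amine, in place of the ethyl of 1-ethyl-1H-pyrazol-4-yl would change the number beyond the scatter.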